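A few compounds are considered here, and "the series" means these few. Any claim that something is new, unique, unknown or untested is made for them only; others in the source may bear on it.

Of the compounds shown here, three sharing one core have been tested in an assay on CHO-K1 cells for displacement of a labelled ligand from prostaglandin E2 receptor EP1 subtype (Homo sapiens), read by scintillation counting, with a stated time of 45 min; on this read-out higher numbers stand for weaker inhibition and lower numbers for stronger inhibition. Compound 1 `Cc1cc(C(=O)O)nn1Cc1cc(Cl)cc2cc(C3CCCCC3)oc12` gives 3.98 nM, compound 2 `CO[C@H]1CC[C@H](NC(=O)c2cc(C)n(Cc3cc(Cl)cc4cc(C(C)C)oc34)n2)CC1` gives 316 nM, and compound 3 `Cc1cc(C(=O)NC(C)(C)C)nn1Cc1cc(Cl)cc2cc(-c3ccccc3)oc12` gives 10 nM. Compound 3 therefore holds the second highest of these three numbers, nearer to compound 1 and far from compound 2, both gaps beyond the scatter. Compound 4 `Cc1cc(C(=O)N[C@H]2CC[C@H](O)CC2)nn1Cc1cc(Cl)cc2cc(-c3ccccc3)oc12` keeps the core of compound 3 and alters one group: 4-hydroxycyclohexyl in place of tert-butyl on an amide-type nitrogen. Going by the values given here, no measured pair differs in exactly this way, so the change has no direct precedent here. In this assay a modest upward step is expected, estimated at a 3.0-fold higher number from compound 3 to compound 4 (0.48 log units; beyond the scatter). Compound 4 is accordingly expected to give about 30 nM, most likely between 8 nM and 120 nM.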

Compound 4, half-maximal inhibitory concentration: 7.94 nM
The estimate for compound 4 lay 3.8-fold (0.58 log units) above the measured number; the whole stated range lies above it.
By their numbers in this assay, from the lowest: compounds 1, 4 and 3 (each within the scatter of the next, the first and the last beyond it); then compound 2.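

Putting 4-hydroxycyclohexyl in place of tert-butyl on the amide-type nitrogen gives a 1.3-fold lower number from compound 3 to compound 4 (0.10 log units; within the scatter) and so shows that this position accepts the larger group, with its ring, hydrogen-bond donor and hydrogen-bond acceptor, without a shift beyond the scatter. Going by these compounds alone, this is the first direct comparison at this position, with the rest of compound 3 held fixed. Nothing here explains why the number holds. Still open, as far as these compounds go, is what a plain cyclohexyl on that nitrogen would give, which would separate the ring from its hydroxyl, and whether a 4-aminocyclohexyl would fit equally well.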